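This account rests on a few compounds, and the source may have more. Where it says the series, first, only, none or still open, it means among the compounds named here.

Measured so far, in a functional assay on SN12C cells (Homo sapiens) for inhibition, read by sulforhodamine B assay, with a stated time of 48 h, tested at 10 uM; on this read-out higher numbers stand for more inhibition at the one concentration tested (going by the name of the read-out) and lower numbers for less inhibition:

Compound 1, `c1ccc2c(-c3cn4ccnc4c(-c4ccc5ncn(C6CCCCC6)c5c4)n3)cccc2c1`, gives 11.7%.
Compound 2, `Brc1ccc(-c2cn3ccnc3c(-c3ccc4ncn(C5CCCCC5)c4c3)n2)cc1`, gives 18.4%.

Going by the values given here, compound 2 stands at one end of these two numbers, with compound 1 as its only neighbour, and the step of a number 6.7 percentage points higher from compound 1 to compound 2 (within the scatter) lies within the scatter, so the two compounds cannot be told apart on this read-out.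

Compound 3, `Fc1ccccc1-c1cn2ccnc2c(-c2ccc3ncn(C4CCCCC4)c3c2)n1`, has not yet been measured. It differs from compound 2 in one place: 2-fluorophenyl in place of 4-bromophenyl on an aromatic carbon

Among the compounds with values here, only one measured step bears on this change. The step of a number 6.7 percentage points higher from compound 1 to compound 2 (within the scatter) also exchanged the group at this same place for another six-membered aromatic ring, and it stayed within the scatter. On that basis no step beyond the scatter is expected for compound 3 in this assay; the expected step is a number 3.4 percentage points lower from compound 2 to compound 3 (within the scatter). The estimate for compound 3 is 15%, expected to fall between 4% and 30%.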

Compound 3, a percentage reported as inhibition, at one concentration (the size of the read-out at that concentration, not a potency): 10.1%
Compound 3: middle estimate off by 4.9 percentage points, on the high side; the range from low to high includes it.
By their numbers in this assay, from the lowest: compounds 3, 1 and 2 (each within the scatter of the next).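

In this assay putting 2-fluorophenyl at this place gives a number 8.3 percentage points lower from compound 2 to compound 3 (within the scatter) and also a number 1.6 percentage points lower from compound 1 to compound 3 (within the scatter) and so all three compounds now sit within the scatter of one another. This place has carried naphthalen-1-yl, 4-bromophenyl and 2-fluorophenyl, and no exchange among these three aromatic groups gives a change that can be told from the scatter. Going from 4-bromophenyl to 2-fluorophenyl alters both the halogen and where it sits on the ring, and even the two alterations together leave the compounds indistinguishable on this read-out.

As far as these compounds go, whether a different kind of group here, such as an amine, a carboxylic acid or a longer alkyl chain, would give a clearly different number remains open. No measurement shown offers an explanation for these numbers.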